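Indole in place of pyridine: tolerance on Vero cells

This account rests on a few compounds, and the source may have more. Where it says the series, first, only, none or still open, it means among the compounds named here.

Compound 1 `Fc1ccc(-c2nn3c(NC4CCCC4)cccc3c2-c2ccc(NC3CCCC3)nc2)cc1`: "not determined" (no result reported)
Compound 2 `Fc1ccc(-c2nn3c(NC4CCCC4)cccc3c2-c2cccnc2)cc1`: > 40000 nM

In an ADME assay on Vero cells (Chlorocebus sabaeus) for cytotoxicity (a higher number here means that more compound is tolerated, a lower number that less compound is tolerated), compound 2 gives only a limit of the assay, > 40000 nM. For compound 1 no result in this assay was reported. Compound 2 therefore stands at the limit of > 40000 nM in this assay, at which 1 of the 2 values shown sits, which tells that a great deal of it is tolerated but gives no exact number.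

Compound 3 `Fc1ccc(-c2nn3c(NC4CCCC4)cccc3c2-c2ccc3[nH]ccc3c2)cc1` is the next step from compound 2. The change is 1H-indol-5-yl in place of pyridin-3-yl on an aromatic carbon. Among the compounds with values here, no step between two measured compounds is available here, so there is nothing to gauge the change against; the expectation is that the step from compound 2 to compound 3 stays within the usual scatter, with no clear direction, and that compound 3 is again reported only as a limit. Compound 3 is expected to give about 40000 nM in this assay, with a range from 20000 nM to 80000 nM. The expected step is a number no higher from compound 2 to compound 3 (the limit leaves the size open).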

Compound 3, half-maximal cytotoxic concentration: 20000 nM
Compound 3: the middle estimate sits 2.0-fold (0.30 log units) above what was measured; measured number inside the range.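

In this assay, within the data shown here, compound 3 gives 20000 nM, the first exact number, so the shared core now has one firm reading of how much compound the cells tolerate. Putting 1H-indol-5-yl in place of pyridin-3-yl on this aromatic carbon gives an at least 2.0-fold lower number from compound 2 to compound 3 (0.30 log units; that floor lies within the scatter), so the change is compatible with a shift too small to tell from scatter, though a larger one is not ruled out. The true size of the step stays unknown because compound 2 is reported only as a limit: the limit of > 40000 nM in this assay, at which 1 of the 3 values shown sits.

Going by these compounds, whether any shift would follow the indole's added ring or its hydrogen-bond donor remains open. A plain phenyl group at this position, or an indole carrying a methyl on its ring nitrogen, would help separate those two features.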